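Replacing methylsulfonyl with fluoro on compound 2

A few compounds are considered here, and "the series" means these few. Any claim that something is new, unique, unknown or untested is made for them only; others in the source may bear on it.

In an in vitro ADME assay on microsomes from liver (Homo sapiens) for metabolic stability (a lower number here means slower removal, a higher number faster removal of the compound), compound 2 `CS(=O)(=O)c1cc(Cl)c(NC(=O)N2CCN3C(=O)N([C@H]4C[C@@H]4c4ccccc4)C(=O)[C@@H]3C2)c(Cl)c1` gives 58000 mL.min-1.g-1 and stands among two relatives sharing its core: compound 1 `O=C(Nc1cccnc1-c1ccsc1)N1CCN2C(=O)N([C@H]3C[C@@H]3c3ccccc3)C(=O)[C@@H]2C1` gives 40000 mL.min-1.g-1 and compound 3 `O=C(Nc1cccnc1-c1ccccc1)N1CCN2C(=O)N([C@H]3C[C@@H]3c3ccccc3)C(=O)[C@@H]2C1` gives 45000 mL.min-1.g-1 in the same test. All three numbers lie within the usual scatter of one another, so compound 2 cannot be ranked against the other two.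

Compound 4 `O=C(Nc1c(Cl)cc(F)cc1Cl)N1CCN2C(=O)N([C@H]3C[C@@H]3c3ccccc3)C(=O)[C@@H]2C1` is still unmeasured and differs from compound 2 in one place. The counted change is fluoro in place of methylsulfonyl on an aromatic carbon and in short it is fluoro in place of methylsulfonyl on an aromatic carbon, meta to two chloro groups and para to a large group.

Going by the values given here, no measured pair makes this exact exchange. Among the compounds with values here, the one measured step is a 1.1-fold higher number from compound 1 to compound 3 (0.05 log units; within the scatter) and it swaps a different group, so it bears on this change only indirectly. Compound 1 and compound 3 carry no methylsulfonyl, yet their numbers stay within the scatter of compound 2 at 58000 mL.min-1.g-1 in this assay and so no step beyond the scatter is expected here. The expected step is a 1.2-fold lower number from compound 2 to compound 4 (0.06 log units; within the scatter) on this reasoning. For compound 4 the estimate is 50000 mL.min-1.g-1 with 24000 mL.min-1.g-1 to 100000 mL.min-1.g-1 as its expected range.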

Compound 4, intrinsic clearance in microsomes: 64000 mL.min-1.g-1
Beside the measured number, compound 4's estimate is 1.3-fold (0.11 log units) below it; measured number inside the range.
By their numbers in this assay, from the lowest: compounds 1, 3, 2 and 4 (each within the scatter of the next).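

In this assay, the step at this position is a 1.1-fold higher number from compound 2 to compound 4 (0.04 log units; within the scatter), so a methylsulfonyl and a fluoro on this aromatic carbon, para to a large group, cannot be told apart, although 4 heavy atoms leave, 1 enters and 2 hydrogen-bond acceptors go. Going by these compounds alone, this is the first direct look at an exchange at this position, as the earlier step concerned a different group on a different ring. The wider exchange of 2,6-dichloro-4-fluorophenyl for 2-(thiophen-3-yl)pyridin-3-yl on the amide-type nitrogen is a 1.6-fold higher number from compound 1 to compound 4 (0.20 log units; within the scatter), so even replacing that whole group leaves the two numbers within the scatter, and no measurement is available that could explain why these numbers sit so close together.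

From the compounds shown here alone, whether an amine or a carboxylic acid at this position would give a step beyond the scatter stays open. Compound 2 and compound 4 also both keep the two chloro groups, so how methylsulfonyl and fluoro would compare on a ring without them is open as well.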